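Swapping Methoxy for Methylamino in a Cytotoxicity Test

This account rests on a few compounds, and the source may have more. Where it says the series, first, only, none or still open, it means among the compounds named here.

In an ADME assay on PBMC cells (Homo sapiens) for cytotoxicity, read by MTT assay (on this read-out higher numbers stand for weaker inhibition and lower numbers for stronger inhibition), compound 3 `COC1=CC(=O)C=C(C[C@]2(C)[C@@H](C)CC[C@]3(C)C(C)=CCC[C@@H]23)C1=O` gives 5900 nM. Going by the values given here, this is the only number available so far, so it cannot yet be ranked against anything. The result for compound 1 `CCCSC1=CC(=O)C(C[C@]2(C)[C@@H](C)CC[C@]3(C)C(C)=CCC[C@@H]23)=CC1=O` is "not determined" (no result reported), and the result for compound 2 `CC1=CCC[C@H]2[C@](C)(CC3=CC(=O)C(SC(C)C)=CC3=O)[C@@H](C)CC[C@]12C` is "not determined" (no result reported). Compound 4 `CNC1=CC(=O)C=C(C[C@]2(C)[C@@H](C)CC[C@]3(C)C(C)=CCC[C@@H]23)C1=O` is still to be measured. It carries methylamino in place of methoxy on a double-bonded ring carbon. Among the compounds with values here, no measured pair shows what a single change does in this assay, so the expectation rests only on compound 3 at 5900 nM: a small move toward weaker inhibition, possibly none beyond the usual scatter. The estimated change is a 1.4-fold higher number from compound 3 to compound 4 (0.13 log units; within the scatter). For compound 4 the expected value is 8000 nM, within an estimated range of 3000 nM to 20000 nM.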

Compound 4, half-maximal inhibitory concentration: 4900 nM
Estimate against measurement, compound 4: 1.6-fold (0.21 log units) above, within the range that was stated.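

In this assay, methylamino in place of methoxy on a double-bonded ring carbon gives a 1.2-fold lower number from compound 3 to compound 4 (0.08 log units; within the scatter). Going by these compounds alone, this is the first single change that can be read at this position, and it shows that the swap, with the hydrogen-bond donor that methylamino brings, stays within the usual scatter. Nothing shown here bears on why the result came out this way.

Compound 1 and compound 2 have no result, so they add no comparison. Going by these compounds, whether a longer chain such as butylamino, or a carboxylic acid, at this ring carbon would go beyond the scatter stays open.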